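A few compounds are considered here, and "the series" means these few. Any claim that something is new, unique, unknown or untested is made for them only; others in the source may bear on it.

Working notes on the series.

Of the compounds shown here, three share a core and have been measured in an assay on CHO cells for displacement of a labelled ligand from 5-hydroxytryptamine receptor 1D (Homo sapiens); a lower number here means a stronger inhibitor, a higher number a weaker inhibitor. Compound 1 `COC[C@H](NC1CCN(CCCc2c[nH]c3ccc(Cn4cncn4)cc23)CC1)c1ccc(F)cc1` gives 5 nM in this assay. Compound 2 `CN(Cc1ccco1)C1CCN(CCCc2c[nH]c3ccc(-n4cnnc4)cc23)CC1` gives 9.3 nM in this assay. Compound 3 `OC[C@H](NC1CCN(CCCc2c[nH]c3ccc(-n4ccnc4)cc23)CC1)c1ccccc1` gives 0.7 nM in this assay. On these numbers compound 2 has the highest value of the three: its gap to compound 1 lies within the scatter, so no order between them is claimed, whereas its gap to compound 3 lies beyond the scatter, so compound 3 is the stronger of that pair.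

Compound 4 `C[C@H](NCC1CCN(CCCc2c[nH]c3ccc(-n4cnnc4)cc23)CC1)c1ccccc1` has not been measured. Relative to compound 2 it carries ((1-phenylethyl)amino)methyl in place of ((furan-2-yl)methyl)(methyl)amino on a saturated ring carbon. For the measured compounds named here, no directly comparable step between measured compounds exists for this change, so the expectation rests on the whole set: both compounds with a hydrogen-bond donor on the amine and a defined stereocentre, compound 1 at 5 nM and compound 3 at 0.7 nM, sit at lower values than compound 2. A modest move to a lower number is therefore expected, with a 3.1-fold lower number from compound 2 to compound 4 (0.49 log units; beyond the scatter) as the estimated step. Compound 4 is estimated at 3 nM in this assay, within a range from 0.8 nM to 12 nM.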

Compound 4, half-maximal inhibitory concentration: 4.4 nM
Beside the measured number, compound 4's estimate is 1.5-fold (0.17 log units) below it; measured number inside the range.
By their numbers in this assay, from the lowest: compound 3; then compounds 4, 1 and 2 (each within the scatter of the next, the first and the last beyond it).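

In this assay, for the compounds shown here, ((1-phenylethyl)amino)methyl in place of ((furan-2-yl)methyl)(methyl)amino on a saturated ring carbon gives a 2.1-fold lower number from compound 2 to compound 4 (0.33 log units; beyond the scatter), the first step that can be read at a single place with the rest of the structure held constant. This position therefore accepts a group with a six-membered aromatic ring of carbon only, a hydrogen-bond donor and a defined stereocentre, with a modest move to a lower number rather than a loss. The data at hand offer no measured property that accounts for this step.

On these data alone, because the change alters several features at once, the part that carries the step remains open. A phenylmethylamino group, the N-methyl form of ((1-phenylethyl)amino)methyl and the opposite stereoisomer at this position would each separate one of these features.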